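The source may hold more compounds than are shown below. What is called first, only, known or untested is meant among the compounds shown, and "the series" means these compounds.

The shared core is that of compound 1 `COc1ccc(-n2cnc3cnc(-c4ccc(F)cc4C)cc32)cc1`. In a functional assay on HL-60 cells (Homo sapiens) for activation, read by flow cytometry, with a stated time of 4 days (a higher number here means that more compound is needed for the effect, a lower number that less compound is needed), compound 1 gives 6 nM. Compound 2 `Cc1ccc(-n2cnc3cnc(-c4ccc(F)cc4C)cc32)cc1` gives 140 nM in this assay, after a 23-fold higher number from compound 1 to compound 2 (1.37 log units; beyond the scatter). Compound 3 `Cc1cc(F)ccc1-c1cc2c(cn1)ncn2-c1ccc(O)nc1` gives > 10000 nM in this assay, which is a limit of the assay and not a number; it sits at the limit of > 10000 nM in this assay, at which 1 of the 3 values shown sits. Compound 3 thus stands at the weak end of the three, reached through an at least 1600-fold higher number from compound 1 to compound 3 (3.22 log units; beyond the scatter) and an at least 71-fold higher number from compound 2 to compound 3 (1.85 log units; beyond the scatter). Compound 4 `COc1cnc(-n2cnc3cnc(-c4ccc(F)cc4C)cc32)cn1` differs from compound 3 by 5-methoxypyrazin-2-yl in place of 6-hydroxypyridin-3-yl on an aromatic nitrogen. The entering group carries a methoxy, as does compound 1, and no hydrogen-bond donor. Both steps into compound 3 were large and upward, so a large downward step is expected: an at least 66-fold lower number from compound 3 to compound 4 (1.82 log units; beyond the scatter). The estimate for compound 4 is 150 nM, ranging from 15 nM to 2500 nM.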

Compound 4, half-maximal effective concentration: 3700 nM
Compound 4: middle estimate off by 25-fold (1.39 log units), on the low side, and the stated range ends below it.
By their numbers in this assay, from the lowest: compound 1; then compound 2; then compound 4. At a limit, above all of these: compound 3.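

At this ring nitrogen a methoxy does not by itself hold the activity: 5-methoxypyrazin-2-yl in place of 4-methoxyphenyl gives a 620-fold higher number from compound 1 to compound 4 (2.79 log units; beyond the scatter). Even against 4-methylphenyl, which carries no methoxy, it gives a 26-fold higher number from compound 2 to compound 4 (1.42 log units; beyond the scatter). Against 6-hydroxypyridin-3-yl it gives an at least 2.7-fold lower number from compound 3 to compound 4 (0.43 log units; beyond the scatter), a step that starts from a limit for compound 3 and not a number: the limit of > 10000 nM in this assay, at which 1 of the 4 values shown sits.

Open, going by these compounds, is how an amine or an ethoxy in place of the methoxy of 4-methoxyphenyl would read here. Also open, on these data alone, is whether a six-membered aromatic ring with one ring nitrogen, keeping the methoxy, would read closer to compound 1.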